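Replacing butyl with 3-(dimethylamino)propyl on compound 1

This account rests on a few compounds, and the source may have more. Where it says the series, first, only, none or still open, it means among the compounds named here.

- compound 1 (`CCCCOc1ccc(C(=O)Nc2cc3ccc(OC4CCN(C)CC4)c(C)c3oc2=O)cc1CC=C(C)C`): 1400 nM
- compound 2 (`CC(=O)Oc1ccc(C(=O)Nc2cc3ccc(OC4CCN(C)CC4)c(C)c3oc2=O)cc1Cl`): 3500 nM

Both values come from a functional assay on SK-BR-3 cells (Homo sapiens) for antiproliferative activity; a higher number here means a weaker inhibitor, a lower number a stronger inhibitor. Compound 1 holds the lower of the two numbers at 1400 nM and compound 2 gives 3500 nM in this assay, a gap beyond the usual scatter. These two compounds differ in more than one place, so their gap cannot be assigned to any single change.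

Compound 3 (`CC(C)=CCc1cc(C(=O)Nc2cc3ccc(OC4CCN(C)CC4)c(C)c3oc2=O)ccc1OCCCN(C)C`) keeps the rest of compound 1 and alters only the end of the ether chain: dimethylamino in place of methyl on a saturated chain carbon, three bonds along the chain from an oxygen on an aromatic ring. This places dimethylamino in place of methyl on a saturated chain carbon, three bonds along the chain from an oxygen on an aromatic ring, so that butyl reads as 3-(dimethylamino)propyl.

For the measured compounds named here, no measured pair isolates this change, so the expectation in this assay is weakly grounded. A small step is expected, perhaps none beyond the scatter, with only a slight lean toward a lower number. The estimated change is a 1.3-fold lower number from compound 1 to compound 3 (0.10 log units; within the scatter) and its direction remains uncertain. For compound 3 the estimated value is 1100 nM with an expected range from 350 nM to 3500 nM.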

Compound 3, half-maximal inhibitory concentration: 250 nM
Estimate against measurement, compound 3: 4.4-fold (0.64 log units) above, outside the stated range (below it).
By their numbers in this assay, from the lowest: compound 3; then compound 1; then compound 2.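

In this assay, for the compounds shown here, replacing butyl with 3-(dimethylamino)propyl gives a 5.6-fold lower number from compound 1 to compound 3 (0.75 log units; beyond the scatter), the first single-place step. It shows that the end of the ether chain is not a silent position: dimethylamino in place of methyl, on a saturated chain carbon three bonds along the chain from an oxygen on an aromatic ring, moves the value beyond the scatter, and compound 3 now holds the lowest number of the three compounds. No measurement in hand bears on the reason for this step, so it stands as an observed change in the antiproliferative read-out and nothing more.

Still open, as far as these compounds go, is whether the step belongs to dimethylamino specifically or would also appear with a morpholine, a primary amine, a hydroxyl or a carboxylic acid at the same chain end. Also open, from the compounds shown here alone, is how it depends on the tether, as with 2-(dimethylamino)ethyl or a longer chain, and a single step cannot show whether the change carries over to other groups on the rest of compound 1.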